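From compound 3 to compound 4: changing the chain on sulfur

The source may report more compounds than this note shows. Statements on the series, on what has been measured and on what is new or still open speak of the compounds shown alone.

Values measured in a functional assay on HT cells (Homo sapiens) for antiproliferative activity, read by fluorescence, with a stated time of 72 h; a lower number here means a stronger inhibitor of growth, a higher number a weaker inhibitor of growth:
- compound 1 `CC(C)c1n[nH]c2c(NCc3ccc(-c4ccccn4)cc3)nc(SCC(O)C(F)(F)F)nc12` gives 690 nM
- compound 2 `CC(C)c1n[nH]c2c(NCc3ccc(-c4ccccn4)cc3)nc(SCC(O)CN3CCNCC3)nc12` gives 332 nM
- compound 3 `CC(C)c1n[nH]c2c(NCc3ccc(-c4ccccn4)cc3)nc(SC(C)C(C)O)nc12` gives 190 nM

Compound 3 is set apart from only one of the other two. The data show a 3.6-fold lower number from compound 1 to compound 3 (0.56 log units; beyond the scatter), but also a 1.7-fold lower number from compound 2 to compound 3 (0.24 log units; within the scatter). In compound 4 `CC(C)c1n[nH]c2c(NCc3ccc(-c4ccccn4)cc3)nc(SCCCO)nc12`, 3-hydroxypropyl stands in place of 2-hydroxy-1-methylpropyl on a sulfur (3-hydroxypropyl in place of 2-hydroxy-1-methylpropyl on a sulfur). Among the compounds with values here, no measured step makes this exact change, so the nearest evidence comes from the other exchanges of the chain on that sulfur. These were modest, as a 2.1-fold lower number from compound 1 to compound 2 (0.32 log units; beyond the scatter) shows, even though those chains differ more from one another than the two compared here. A small step is therefore expected in this assay, most likely a slight rise in the number that stays within the scatter. The expected change is a 1.3-fold higher number from compound 3 to compound 4 (0.12 log units; within the scatter). The estimate for compound 4 is 250 nM, with an expected range from 110 nM to 560 nM.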

Compound 4, concentration for 50% growth inhibition: 109 nM
The estimate for compound 4 lay 2.3-fold (0.36 log units) above the measured number, and the stated range ends above it.
By their numbers in this assay, from the lowest: compounds 4, 3 and 2 (each within the scatter of the next, the first and the last beyond it); then compound 1.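

In this assay, 3-hydroxypropyl on the sulfur holds level with 2-hydroxy-1-methylpropyl, with a 1.7-fold lower number from compound 3 to compound 4 (0.24 log units; within the scatter) in this exchange, so the smaller chain loses nothing measurable here. It also stands clear of both remaining chains, with a 3.0-fold lower number from compound 2 to compound 4 (0.48 log units; beyond the scatter) against the chain bearing piperazine and a 6.3-fold lower number from compound 1 to compound 4 (0.80 log units; beyond the scatter) against the chain bearing trifluoromethyl, whereas compound 3 stood clear of compound 1 only. Nothing at hand explains these differences.

Whether the hydroxyl on the chain is needed at all stays open, since every compound shown carries one. Also open, going by these compounds, is how a longer chain such as 4-hydroxybutyl, or an amine or a carboxylic acid at the end of the three-carbon chain in place of the hydroxyl, would compare with compound 4 in this assay on this shared core.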